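Compound 4: a chloro on the phenyl of compound 2

The source may report more compounds than this note shows. Statements on the series, on what has been measured and on what is new or still open speak of the compounds shown alone.

Compound 2 `O=C1C(N2CCCC2)=NN(c2ccccc2)CN1c1ccccc1Cl` gives the highest of the three numbers shown in an ADME assay on HUVEC cells (Homo sapiens) for antiproliferative activity, read by resazurin assay, with a stated time of 72 h (a lower number here means a stronger inhibitor of growth, a higher number a weaker inhibitor of growth), at 40.9 ug/mL, though within the scatter of both others. Compound 1 `CN(C)C1=NN(c2ccccc2)CN(c2ccccc2Cl)C1=O` gives 34.5 ug/mL and compound 3 `O=C1C(N2CCCCC2)=NN(c2ccccc2)CN1c1ccccc1Cl` gives 24.7 ug/mL; the steps of a 1.2-fold higher number from compound 1 to compound 2 (0.07 log units; within the scatter) and a 1.7-fold lower number from compound 2 to compound 3 (0.22 log units; within the scatter) fall within the scatter, as does a 1.4-fold lower number from compound 1 to compound 3 (0.15 log units; within the scatter). Compound 4 `O=C1C(N2CCCC2)=NN(c2ccc(Cl)cc2)CN1c1ccccc1Cl` differs from compound 2 by chloro in place of hydrogen on an aromatic carbon. For the measured compounds named here, none of the measured steps touches that phenyl ring; all three concern only the amino group, and none moved beyond the scatter. With nothing bearing directly on this change, the step of a 1.0-fold lower number from compound 2 to compound 4 (0.01 log units; within the scatter) is expected to remain within the scatter. The estimate for compound 4 in this assay is 40 ug/mL, with a range from 20 ug/mL to 80 ug/mL.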

Compound 4, concentration for 50% growth inhibition: 18.9 ug/mL
Compound 4: middle estimate off by 2.1-fold (0.33 log units), on the high side; measured number outside the range, below it.
By their numbers in this assay, from the lowest: compounds 4, 3, 1 and 2 (each within the scatter of the next, the first and the last beyond it).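

In this assay chloro in place of hydrogen on the phenyl ring, para to a large group, gives a 2.2-fold lower number from compound 2 to compound 4 (0.34 log units; beyond the scatter) and is the only step shown beyond the scatter, though a modest one. The amino group steps among dimethylamino, pyrrolidin-1-yl and piperidin-1-yl all stayed within it, so this ring position is the one place shown where a change registers. Nothing measured here accounts for the step. As far as these compounds go, whether methyl, methoxy or a carboxylic acid at this position would act like chloro stays open. So does whether the 4-chlorophenyl change would hold with piperidin-1-yl as the amino group.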